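Compound 3 to compound 4 at the limit

The source may report more compounds than this note shows. Statements on the series, on what has been measured and on what is new or still open speak of the compounds shown alone.

In an ADME assay on HBZY-1 cells (Rattus norvegicus) for cytotoxicity, read by MTT assay, with a stated time of 2 h (a higher number here means a weaker inhibitor, a lower number a stronger inhibitor), compound 1 (`COc1ccc(NC(=O)/C=C/c2ccccc2C(F)(F)F)cc1OC`) gives > 200000 nM, which is a limit and not a number. Compound 2 (`COc1cc(NC(=O)/C(C#N)=C/c2ccccc2C(F)(F)F)cc(OC)c1OC`) gives > 200000 nM, again a limit. Compound 3 (`COc1ccc(CNC(=O)/C(C#N)=C/c2ccccc2C(F)(F)F)cc1`) gives > 200000 nM, also a limit. Compound 3 therefore has no numerical value and stands with the other two: the series shows (the limit of > 200000 nM in this assay, at which 3 of the 3 values shown sit).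

The next step leads to compound 4 (`CCCCNC(=O)/C(C#N)=C/c1ccccc1C(F)(F)F`). The change is propyl in place of 4-methoxyphenyl on a saturated chain carbon bound to an amide-type nitrogen, with propyl in place of 4-methoxyphenyl on a saturated chain carbon bound to an amide-type nitrogen.

Among the compounds with values here, no step between measured compounds is available to size this change. The expectation in this assay rests on (the limit of > 200000 nM in this assay, at which 3 of the 3 values shown sit), and it is for no shift in either direction beyond the scatter. The estimated a number no higher from compound 3 to compound 4 (the limit leaves the size open) is accordingly expected to be small, and a further limit is the likely report. For compound 4 the estimated value is 200000 nM, with an expected range of 100000 nM to 400000 nM.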

Compound 4, half-maximal inhibitory concentration: > 200000 nM
Compound 4 ended at the assay's limit; the forecaster's own chance of this, stated with the estimate: 85%; the middle value lies on the limit itself.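

No new step can be read: compound 3 and compound 4 each give only a limit and not a number, so propyl in place of 4-methoxyphenyl has no readable size. The compounds shown leave open whether any structural change in this series shifts the read-out: the limit of > 200000 nM in this assay, at which 4 of the 4 values shown sit.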